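This account rests on a few compounds, and the source may have more. Where it says the series, first, only, none or still open, it means among the compounds named here.

Measured in a functional assay on the whole organism for inhibition, with Rattus norvegicus as the target, at a dose of 10 mg/kg by the oral route; a higher number here means a stronger effect of the compound at the dose given, a lower number a weaker effect:
- compound 1 `O=C(Nc1nn[nH]n1)c1cccc(Br)n1` gives 48%
- compound 2 `O=C(Nc1nn[nH]n1)c1ccccn1` gives 35%

Compound 2 stands lowest of the two numbers; its nearest is compound 1. For the measured compounds named here, the single measured step is a number 13 percentage points lower from compound 1 to compound 2 (beyond the scatter). Compound 3 `CCCc1cccc(C(=O)Nc2nn[nH]n2)n1` differs from compound 2 by propyl in place of hydrogen on an aromatic carbon. The step from compound 1 to compound 2 bears on this, as it also concerns a substituent on an aromatic carbon of the shared core, and a modest change in this assay is therefore expected in the upward direction for compound 3, estimated as a number 10 percentage points higher from compound 2 to compound 3 (within the scatter). Compound 3 is expected to give 45%, within a range of 25% to 65%.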

Compound 3, a percentage reported as inhibition, in the whole organism at one dose (the size of the read-out at that dose, not a potency): 38%
Beside the measured number, compound 3's estimate is 7 percentage points above it; low and high end bracket the measured number.
By their numbers in this assay, from the lowest: compounds 2, 3 and 1 (each within the scatter of the next, the first and the last beyond it).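

Propyl in place of hydrogen on the aromatic carbon next to the ring nitrogen gives, in this assay, a number 3 percentage points higher from compound 2 to compound 3 (within the scatter), so this change does not separate the two compounds at this dose. Propyl in place of bromo gives a number 10 percentage points lower from compound 1 to compound 3 (within the scatter), which leaves compound 3 within the scatter of both neighbours, although bromo and hydrogen lie beyond it from each other. Nothing available explains these numbers.

Open, on these data alone, is whether an amine or a longer chain at this position would move the number beyond the scatter from hydrogen. Also open, as far as these compounds go, is whether these readings would hold at other doses.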